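Removing the sulfonamide propyl group from compound 2

This account rests on a few compounds, and the source may have more. Where it says the series, first, only, none or still open, it means among the compounds named here.

In a functional assay on Huh-7 cells (Homo sapiens) for antiproliferative activity, read by CCK-8 assay, with a stated time of 72 h (on this read-out lower numbers stand for stronger inhibition of growth and higher numbers for weaker inhibition of growth), compound 2 `CCCNS(=O)(=O)c1ccc(Nc2ncc3c(n2)N(c2ccn(C)n2)C(CC)C(=O)N3C)cc1` gives 8880 nM, within the scatter of compound 1 `CCC1C(=O)N(C)c2cnc(Nc3ccc(S(=O)(=O)NCC(C)C)cc3)nc2N1c1ccn(C)n1` at 8520 nM and of compound 3 `CCCCNC(=O)c1ccc2c(ccn2-c2ncc3c(n2)N(c2ccn(C)n2)C(CC)C(=O)N3C)c1` at 8670 nM. Compound 4 `CCC1C(=O)N(C)c2cnc(Nc3ccc(S(N)(=O)=O)cc3)nc2N1c1ccn(C)n1` differs from compound 2 by hydrogen in place of propyl on a sulfonamide nitrogen. Among the compounds with values here, one measured step bears on this sulfonamide substituent: a 1.0-fold higher number from compound 1 to compound 2 (0.02 log units; within the scatter), within the scatter. Within the data shown here, that step shortens the chain without removing it, and no measured compound carries the unsubstituted sulfamoyl group, so the guidance is limited. No shift beyond the scatter is expected, and the estimated change is a 1.3-fold lower number from compound 2 to compound 4 (0.10 log units; within the scatter). For compound 4 the estimated value is 7000 nM, with an expected range of 2000 nM to 25000 nM.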

Compound 4, concentration for 50% growth inhibition: "not active" (no number reported)
Nothing numeric was reported for compound 4; no gap can be computed for the estimate.
By their numbers in this assay, from the lowest: compounds 1, 3 and 2 (each within the scatter of the next).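

Within the data shown here, compound 4 is reported as not active, without a number, so no step from compound 2 can be read. From the compounds shown here alone, how far compound 4 lies from compound 2 stays open. No evidence shown accounts for this result.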